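The source may hold more compounds than are shown below. What is called first, only, known or untested is meant among the compounds shown, and "the series" means these compounds.

Compound 2 `C/C=C/C(=O)N(Cc1ccc(OC)c(C)c1)c1cc(OC)c(OC)c(OC)c1` gives 32900 nM in a functional assay on KYSE-450 cells (Homo sapiens) for inhibition, read by MTT assay, with a stated time of 48 h (a higher number here means a weaker inhibitor, a lower number a stronger inhibitor), and stands second highest of the three numbers measured. Compound 1 `COc1ccc(CNc2cc(OC)c(OC)c(OC)c2)cc1C` gives 73800 nM in this assay, and the step of a 2.2-fold lower number from compound 1 to compound 2 (0.35 log units; beyond the scatter) is modest. Compound 3 `COc1ccc(CN(C(=O)/C=C/CBr)c2cc(OC)c(OC)c(OC)c2)cc1O` gives 100 nM in this assay, far below compound 2. Compound 4 `C/C=C/C(=O)N(Cc1ccc(OC)cc1)c1cc(OC)c(OC)c(OC)c1` differs from compound 2 by hydrogen in place of methyl on an aromatic carbon. Among the measured compounds shown here, none of the measured steps changes this part of the structure: the step of a 2.2-fold lower number from compound 1 to compound 2 (0.35 log units; beyond the scatter) concerns the nitrogen, and compound 3 differs from compound 2 in more than one place, so its value shows only that much lower numbers are reachable on the shared core. With nothing bearing on the change, the expected step is a 1.1-fold higher number from compound 2 to compound 4 (0.03 log units; within the scatter), within the scatter. Compound 4 is therefore estimated at 35000 nM, between 15000 nM and 80000 nM.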

Compound 4, half-maximal inhibitory concentration: 420 nM
The estimate for compound 4 lay 83-fold (1.92 log units) above the measured number, outside the stated range (below it).
By their numbers in this assay, from the lowest: compound 3; then compound 4; then compound 2; then compound 1.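

In this assay, among the compounds shown here, going from 4-methoxy-3-methylphenyl to 4-methoxyphenyl gives a 78-fold lower number from compound 2 to compound 4 (1.89 log units; beyond the scatter), a large step and the first measured change on this aromatic ring. A single methyl group on this aromatic carbon, ortho to a methoxy group, thus separates two compounds that are otherwise identical, and this step far exceeds the modest 2.2-fold lower number from compound 1 to compound 2 (0.35 log units; beyond the scatter) at the nitrogen. Nothing available accounts for the size of this step. As far as these compounds go, whether a fluorine atom, a chlorine atom or an ethyl group here would track hydrogen or methyl remains open. So does whether this change gives a similar step with the amide group of compound 3.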